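The source may hold more compounds than are shown below. What is called first, only, known or untested is meant among the compounds shown, and "the series" means these compounds.

Values in a functional assay on QGY-7703 cells (Homo sapiens) for cytotoxicity, read by MTT assay, with a stated time of 24 h; on this read-out higher numbers stand for weaker inhibition and lower numbers for stronger inhibition:
- Compound 1 `O=C1/C(=C/c2ccncc2)CN(S(=O)(=O)c2ccccc2)C/C1=C\c1ccccc1F`: 8400 nM
- Compound 2 `O=C1/C(=C/c2ccncc2)CN(S(=O)(=O)c2ccc(C(F)(F)F)cc2)C/C1=C\c1ccccc1F`: 9500 nM
- Compound 3 `O=C1/C(=C/c2ccncc2)CN(S(=O)(=O)c2ccccc2)C/C1=C\c1ccccc1C(F)(F)F`: 6210 nM

The value of compound 3 lies within the usual scatter of those of compound 1 and compound 2, so the three do not separate. Compound 4 `O=C1/C(=C/c2ccncc2)CN(S(=O)(=O)c2ccc(C(F)(F)F)cc2)C/C1=C\c1ccccc1C(F)(F)F` differs from compound 3 by trifluoromethyl in place of hydrogen on an aromatic carbon, para to a large group. The same change was measured once, as a 1.1-fold higher number from compound 1 to compound 2 (0.05 log units; within the scatter). The other measured step, a 1.4-fold lower number from compound 1 to compound 3 (0.13 log units; within the scatter), is a different substitution and bears on it only indirectly. Neither leaves the scatter, so no real shift is expected in this assay. The expected step is a 1.1-fold higher number from compound 3 to compound 4 (0.05 log units; within the scatter), none beyond the scatter. The estimate for compound 4 is 7000 nM, with an expected range from 3800 nM to 13000 nM.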

Compound 4, half-maximal inhibitory concentration: 4680 nM
The estimate for compound 4 lay 1.5-fold (0.17 log units) above the measured number; the measured number falls inside the stated range.
By their numbers in this assay, from the lowest: compounds 4, 3, 1 and 2 (each within the scatter of the next, the first and the last beyond it).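

In this assay the change from phenyl to 4-(trifluoromethyl)phenyl gives a 1.3-fold lower number from compound 3 to compound 4 (0.12 log units; within the scatter) on a second core and so agrees with the first reading: the same change on two cores in this assay, a 1.1-fold higher number (0.05 log units; within the scatter) from compound 1 to compound 2 and a 1.3-fold lower number (0.12 log units; within the scatter) from compound 3 to compound 4, 1.5-fold (0.18 log units) apart, within the scatter of two such steps. Trifluoromethyl in place of fluoro gives a 2.0-fold lower number from compound 2 to compound 4 (0.31 log units; beyond the scatter) and is the first step here to leave the scatter, if only modestly, yet it does not separate from the same change on the core of compound 1: the same change on two cores in this assay, a 1.4-fold lower number (0.13 log units; within the scatter) from compound 1 to compound 3 and a 2.0-fold lower number (0.31 log units; beyond the scatter) from compound 2 to compound 4, 1.5-fold (0.18 log units) apart, within the scatter of two such steps. Open, from the compounds shown here alone, is whether an amine or a carboxylic acid on that aromatic carbon, in place of trifluoromethyl, would move the number beyond the scatter.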